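Swapping a halogenated aryl urea for a trifluoromethyl one

The source may hold more compounds than are shown below. What is called first, only, known or untested is meant among the compounds shown, and "the series" means these compounds.

Two compounds built on a shared core were tested in a functional assay on NCI-H226 cells (Homo sapiens) for inhibition, read by sulforhodamine B assay, with a stated time of 48 h, tested at 0.1 uM; on this read-out lower numbers stand for a stronger effect and higher numbers for a weaker effect at the one concentration tested. Compound 1 `COc1cc(Cl)cc(-c2nn(-c3cccc(NC(=O)Nc4cc(C(F)(F)F)cc(C(F)(F)F)c4)c3)cc2-c2ccncc2)c1` gives 102% in this assay. Compound 2 `COc1cc(Cl)cc(-c2nn(-c3cccc(NC(=O)Nc4ccc(Cl)c(Cl)c4)c3)cc2-c2ccncc2)c1` gives 96% in this assay, the lower of the two numbers, though the gap to compound 1 lies within the scatter, so the two read-outs cannot be told apart. Both sit near the level that means no measurable effect at this concentration.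

Compound 3 `COc1cc(Cl)cc(-c2nn(-c3cccc(NC(=O)Nc4cccc(C(F)(F)F)c4)c3)cc2-c2ccncc2)c1` has not yet been measured. It differs from compound 2 in one place: 3-(trifluoromethyl)phenyl in place of 3,4-dichlorophenyl on an amide-type nitrogen. Within the data shown here, no step between measured compounds isolates this change, so the expectation rests on the two numbers alone. Since both measured compounds show essentially no effect, the step of a number 3 percentage points higher from compound 2 to compound 3 (within the scatter) is expected to stay within the scatter, in no clear direction. Compound 3 is estimated to give 99% in this assay, with a range from 86% to 110%.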

Compound 3, a percentage reported as activity, at one concentration (the size of the read-out at that concentration, not a potency): 95%
Estimate against measurement, compound 3: 4 percentage points above; the range from low to high includes it.
By their numbers in this assay, from the lowest: compounds 3, 2 and 1 (each within the scatter of the next).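

In this assay, the step with 3-(trifluoromethyl)phenyl in place of 3,4-dichlorophenyl on the amide-type nitrogen is a number 1 percentage points lower from compound 2 to compound 3 (within the scatter) and so cannot separate these two aryl groups at the one concentration tested. The comparison with the compound carrying an extra trifluoromethyl, where hydrogen stands in its place on an aromatic carbon, is a number 7 percentage points lower from compound 1 to compound 3 (within the scatter), so this aryl group tolerates that edit without a measurable difference in this read-out. Nothing measured here offers an explanation for either result.

All three compounds sit near the level of no measurable effect, so these comparisons cannot show whether the groups would differ at a higher concentration. As far as these compounds go, whether a carboxylic acid or an amine on this aryl ring would produce a measurable effect also remains open.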